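The compounds below may be only part of what the source reports. "The series", "measured", "known", "first", "only" and "open" are said of these compounds alone.

Three compounds have been measured in a functional assay on NCI-H1299 cells (Homo sapiens) for inhibition, read by CCK-8 assay, with a stated time of 72 h, tested at 10 uM; on this read-out lower numbers stand for less inhibition of growth and higher numbers for more inhibition of growth at the one concentration tested:

Compound 1, `CN(C)C(=O)c1cc2cnc(Nc3ccc(NC(=O)C4(C(=O)Nc5ccccc5)CC4)cc3)nc2n1C1CCCC1`: 90.5%
Compound 2, `CN(C)C(=O)c1cc2cnc(Nc3ccc(NC(=O)C4(C(=O)Nc5ccccc5F)CC4)cc3)nc2n1C1CCCC1`: 89.6%
Compound 3, `Cc1ccc(NC(=O)C2(C(=O)Nc3ccc(Nc4ncc5cc(C(=O)N(C)C)n(C6CCCC6)c5n4)cc3)CC2)cc1`: 84.5%

Compound 3 gives the smallest of these three numbers, yet the step of a number 6 percentage points lower from compound 1 to compound 3 (within the scatter) and the step of a number 5.1 percentage points lower from compound 2 to compound 3 (within the scatter) are both within the scatter, so the three compounds cannot be told apart on this read-out.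

Compound 4, `CN(C)C(=O)c1cc2cnc(Nc3ccc(NC(=O)C4(C(=O)Nc5ccc(O)cc5)CC4)cc3)nc2n1C1CCCC1`, has not yet been measured. It differs from compound 3 in one place: hydroxy in place of methyl on an aromatic carbon. The outer ring thus changes from 4-methylphenyl to 4-hydroxyphenyl.

The steps seen so far all touch this same outer ring. Fluoro in place of hydrogen gave a number 0.9 percentage points lower from compound 1 to compound 2 (within the scatter), methyl in place of hydrogen gave a number 6 percentage points lower from compound 1 to compound 3 (within the scatter), and swapping the whole ring gave a number 5.1 percentage points lower from compound 2 to compound 3 (within the scatter). None of these reached beyond the scatter, so small changes on this ring have not shifted the growth inhibition so far. Whether a hydroxy group behaves the same is not shown by any measured pair; the expectation can rest only on the three within-scatter steps.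

For compound 4 the expected step is a number 1.5 percentage points higher from compound 3 to compound 4 (within the scatter). Compound 4 is therefore estimated at 86%, with a range from 74% to 94%.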

Compound 4, percent growth inhibition at one concentration: 89.7%
The estimate for compound 4 lay 3.7 percentage points below the measured number; the range from low to high includes it.
By their numbers in this assay, from the lowest: compounds 3, 2, 4 and 1 (each within the scatter of the next).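

With hydroxy on this aromatic carbon, para to a large group, the outer ring gains one hydrogen-bond donor and one hydrogen-bond acceptor, which hydrogen, fluoro and methyl do not bring, yet in this assay the exchange for methyl gives a number 5.2 percentage points higher from compound 3 to compound 4 (within the scatter), a step within the scatter. The comparisons with the other two outer rings give a number 0.1 percentage points higher from compound 2 to compound 4 (within the scatter) and a number 0.8 percentage points lower from compound 1 to compound 4 (within the scatter), also within the scatter, so the four compounds cannot be told apart on this read-out, and adding a hydroxy group with its donor and acceptor has not shifted growth inhibition at the one concentration tested. No other kind of measurement is available to explain this result.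

As far as these compounds go, it remains open whether a different group at this place, such as an amine, a carboxylic acid or a longer chain, would move the number beyond the scatter. With only one concentration shown, it also remains open whether these four compounds would separate at lower concentrations, where a difference hidden here might appear.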